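A few compounds are considered here, and "the series" means these few. Any claim that something is new, unique, unknown or untested is made for them only; others in the source may bear on it.

Measured in an ADME assay on MT4 cells (Homo sapiens) for cytotoxicity, read by MTT assay, with a stated time of 5 days; a lower number here means that less compound is tolerated, a higher number that more compound is tolerated:
- compound 1 `Cc1cc(C#N)cc(C)c1Oc1cc(Nc2ccc(C#N)cc2)[nH]c(=O)c1Cl`: > 319000 nM (a limit of the assay)
- compound 2 `Cc1cccc(C)c1Oc1cc(Nc2ccc(C#N)cc2)[nH]c(=O)c1Cl`: 29000 nM

Going by the values given here, compound 2 holds the only actual number so far. Compound 1 gives a limit and not a number: the limit of > 319000 nM in this assay, at which 1 of the 2 values shown sits.

Compound 3 `Cc1cccc(C)c1Oc1cc(Nc2ccc(C#N)cc2)[nH]c(=O)c1` is compound 2 with hydrogen in place of chloro on an aromatic carbon, on a six-membered aromatic ring with 1 nitrogen: hydrogen in place of chloro on an aromatic carbon.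

Among the compounds with values here, the one measured step is an at least 11-fold lower number from compound 1 to compound 2 (1.04 log units; beyond the scatter). That step is large, but it replaces cyano rather than chloro and lies at a different place, so it offers no direct guide to size or direction here. Within the data shown here, with no measured step on this change, no shift beyond the scatter is expected in this assay.

The expected result is a 1.0-fold higher number from compound 2 to compound 3 (0.01 log units; within the scatter). For compound 3 the estimate is 30000 nM, with an expected range from 10000 nM to 100000 nM.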

Compound 3, half-maximal cytotoxic concentration: 36000 nM
Compound 3: the middle estimate sits 1.2-fold (0.08 log units) below what was measured; the measured number falls inside the stated range.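

In this assay, hydrogen in place of chloro gives a 1.2-fold higher number from compound 2 to compound 3 (0.09 log units; within the scatter), so chloro and hydrogen on this aromatic carbon cannot be told apart in this read-out. This position therefore shows none of the sensitivity seen at the other site, where hydrogen in place of cyano gives an at least 11-fold lower number from compound 1 to compound 2 (1.04 log units; beyond the scatter). Nothing measured here bears on a cause for the step at the chloro position.

Open, as far as these compounds go, is how this carbon responds to a bulkier or charged substituent, such as a methoxy group, an amine or a carboxylic acid. Also open, from the compounds shown here alone, is whether hydrogen in place of chloro reads the same on compound 1, whose > 319000 nM is a limit of the assay.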